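From hydroxy to dichloro on a shared core

The source may hold more compounds than are shown below. What is called first, only, known or untested is meant among the compounds shown, and "the series" means these compounds.

In an ADME assay on NHDF cells (Homo sapiens) for cytotoxicity, read by MTT assay, with a stated time of 72 h (a higher number here means a weaker inhibitor, a lower number a stronger inhibitor), three compounds with a shared core have been measured. Compound 1 `COc1ccc(/C=C2\CCC/C(=C\c3ccc(Cl)cc3)C2=O)cc1OC` reads 11200 nM here, and compound 2 `COc1ccc(/C=C2\CCC/C(=C\c3cccc(Br)c3)C2=O)cc1OC` reads 12400 nM here, a pair separated by a 1.1-fold higher number from compound 1 to compound 2 (0.04 log units; within the scatter) in this series. Compound 3 `COc1ccc(/C=C2\CCC/C(=C\c3ccc(O)cc3)C2=O)cc1OC` reads 26100 nM and so holds the highest number of the three.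

Compound 4 `COc1ccc(/C=C2\CCC/C(=C\c3ccc(Cl)cc3Cl)C2=O)cc1OC` has not yet been measured. Its difference from compound 3 is 2,4-dichlorophenyl in place of 4-hydroxyphenyl on a double-bonded chain carbon bound to a double-bonded ring carbon and amounts to 2,4-dichlorophenyl in place of 4-hydroxyphenyl on a double-bonded chain carbon bound to a double-bonded ring carbon. For the measured compounds named here, two measured steps bear most directly on this change. There is a 2.3-fold higher number from compound 1 to compound 3 (0.37 log units; beyond the scatter) when hydroxy replaces chloro, and there is a 2.1-fold higher number from compound 2 to compound 3 (0.32 log units; beyond the scatter) when 4-hydroxyphenyl replaces 3-bromophenyl. Both are modest, both lie beyond the scatter, and both run opposite to the change now in question. Going by the values given here, no measured compound carries 2,4-dichlorophenyl, so the group itself remains untested.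

Compound 4 is therefore expected to fall near compound 1 and compound 2 rather than near compound 3. The expected change is a 2.3-fold lower number from compound 3 to compound 4 (0.36 log units; beyond the scatter) and it would be modest in size. In this assay compound 4 is estimated at 11500 nM with an expected range of 5500 nM to 22000 nM once measured.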

Compound 4, half-maximal inhibitory concentration: > 50000 nM
Compound 4 was reported as a limit; the forecaster's own chance of this, stated with the estimate: 3%; middle value at least 4.3-fold (0.63 log units) away from the limit.
By their numbers in this assay, from the lowest: compounds 1 and 2 (each within the scatter of the next); then compound 3. At a limit, above all of these: compound 4.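

In this assay, chloro in place of hydrogen on an aromatic carbon gives an at least 4.4-fold higher number from compound 1 to compound 4 (0.64 log units; beyond the scatter), and 2,4-dichlorophenyl in place of 3-bromophenyl gives an at least 4.0-fold higher number from compound 2 to compound 4 (0.60 log units; beyond the scatter), so at this position a halogen-bearing phenyl does not in itself keep the number low, as compounds 1 and 2 alone had suggested. Set against the hydroxy compound, the change gives an at least 1.9-fold higher number from compound 3 to compound 4 (0.28 log units; that floor lies within the scatter), so compound 4 stands above compound 3 in the printed order, yet the size of that step is not established beyond the scatter. Compound 4 is the only compound in this set that reads as a limit of the assay rather than as a number: the limit of > 50000 nM in this assay, at which 1 of the 4 values shown sits.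

The compounds shown do not tell whether the second chloro or the 2,4-dichlorophenyl pattern as a whole accounts for the step from compound 1, and how far compound 4 lies past its limit stays open. Also open, from the compounds shown here alone, is how a difluorophenyl, or a phenyl carrying an amine or a carboxylic acid, would read on this double-bonded chain carbon.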